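The source may hold more compounds than are shown below. What is called first, only, known or untested is meant among the compounds shown, and "the series" means these compounds.

Compound 1 `O=C(C1=C(O)C(=O)N(c2ccc(-c3ccon3)cc2)C1C1CCCCC1)c1ccc(CO)cc1` and compound 2 `O=C(O)c1ccc(C(=O)C2=C(O)C(=O)N(c3ccc(-c4ccon4)cc3)C2C2CCCCC2)cc1` share one core and differ at a single aromatic carbon. In a physicochemical assay for solubility, in phosphate buffer, at pH 6.8 (on this read-out lower numbers stand for lower solubility and higher numbers for higher solubility), compound 1 gives > 50000 nM, a limit of the assay rather than a number. In this assay compound 2 likewise gives > 50000 nM, again a limit. The step that the two limits leave unreadable from compound 1 to compound 2 therefore cannot be sized, since (the limit of > 50000 nM in this assay, at which 2 of the 2 values shown sit). Compound 2 thus stands at that limit, with no number to place it more precisely. Compound 3 `CNC(=O)c1ccc(C(=O)C2=C(O)C(=O)N(c3ccc(-c4ccon4)cc3)C2C2CCCCC2)cc1` differs from compound 2 by methylamino in place of hydroxy on a carbonyl carbon. Among the measured compounds shown here, the only measured step that bears on this change is the one from compound 1 to compound 2, and its size is hidden by the two limits, so no direction can be read from it. For compound 3 the expectation is that this assay again returns a high value, with the step of a number no higher from compound 2 to compound 3 (the limit leaves the size open) expected to be small or none beyond the scatter. Compound 3 is estimated at 50000 nM, between 8000 nM and 150000 nM.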

Compound 3, solubility: 27000 nM
Beside the measured number, compound 3's estimate is 1.9-fold (0.27 log units) above it; measured number inside the range.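

Compound 3 is the first compound shown in this assay to give a number rather than a limit, so a change on this aromatic carbon can now register on the scale. Putting methylcarbamoyl there brings an at least 1.8-fold lower number from compound 2 to compound 3 (0.26 log units; that floor lies within the scatter) and an at least 1.8-fold lower number from compound 1 to compound 3 (0.26 log units; that floor lies within the scatter); these are floors within the scatter, so neither yet shows a real drop. Going by these compounds, how far either step truly reaches stays open: the limit of > 50000 nM in this assay, at which 2 of the 3 values shown sit.

The compounds shown leave open whether this number belongs to the amide as such or to its methyl group, which carbamoyl or ethylcarbamoyl on the same aromatic carbon would separate. Among the compounds shown here, they also leave open how an amine at that carbon would read, since only three groups have been placed there so far.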